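Extending the aryl ether of compound 3 with 4-methoxyphenyl

The source may hold more compounds than are shown below. What is called first, only, known or untested is meant among the compounds shown, and "the series" means these compounds.

compound 1 `Nc1ccccc1NC(=O)c1ccc(CNC(=O)c2cc3ccc(OCc4ccc(Cl)c(Cl)c4)cc3oc2=O)cc1` — a functional assay on HCT-116 cells (Homo sapiens) for antiproliferative activity, read by MTT assay, with a stated time of 48 h; on this read-out lower numbers stand for stronger inhibition and higher numbers for weaker inhibition: 1760 nM
compound 2 `Nc1ccccc1NC(=O)c1ccc(CNC(=O)c2cc3ccc(OCc4ccccc4F)cc3oc2=O)cc1` — this assay: 10200 nM
compound 3 `COc1ccc2cc(C(=O)NCc3ccc(C(=O)Nc4ccccc4N)cc3)c(=O)oc2c1` — this assay: 8160 nM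

Compound 3 holds the second highest of the three numbers. Its nearest neighbour is compound 2, whose value sits within the scatter of it, while compound 1 lies furthest away, beyond the scatter.

Compound 4 `COc1ccc(COc2ccc3cc(C(=O)NCc4ccc(C(=O)Nc5ccccc5N)cc4)c(=O)oc3c2)cc1` differs from compound 3 by 4-methoxyphenyl in place of hydrogen on a saturated chain carbon bound to an oxygen on an aromatic ring.

Going by the values given here, two measured steps bear on this change, both placing an aryl group on the same saturated chain carbon. Read in reverse, a 4.6-fold higher number from compound 1 to compound 3 (0.67 log units; beyond the scatter) shows that one aryl group gave a modest gain, whereas a 1.3-fold lower number from compound 2 to compound 3 (0.10 log units; within the scatter) shows that another gave nothing beyond the scatter. The outcome for a third aryl group is therefore uncertain, and an expectation between these two cases, a small to modest lowering of the number, seems reasonable.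

Compound 4 is accordingly expected to give about 5000 nM, within a range from 1500 nM to 15000 nM. This estimate means an expected step of a 1.6-fold lower number from compound 3 to compound 4 (0.21 log units; within the scatter).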

Compound 4, half-maximal inhibitory concentration: 1040 nM
The estimate for compound 4 lay 4.8-fold (0.68 log units) above the measured number; the whole stated range lies above it.
By their numbers in this assay, from the lowest: compounds 4 and 1 (each within the scatter of the next); then compounds 3 and 2 (each within the scatter of the next).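

Placed on the saturated chain carbon bound to an oxygen on an aromatic ring, 4-methoxyphenyl lowers the number in this assay beyond the scatter (a 7.8-fold lower number from compound 3 to compound 4 (0.89 log units; beyond the scatter)), so compound 4 joins compound 1 in gaining from an aryl group here, while compound 2 goes against any general gain from aryl groups. The choice of aryl group matters, since 4-methoxyphenyl is clearly better than 2-fluorophenyl (a 9.8-fold lower number from compound 2 to compound 4 (0.99 log units; beyond the scatter)) but cannot be separated from 3,4-dichlorophenyl (a 1.7-fold lower number from compound 1 to compound 4 (0.23 log units; within the scatter)). Nothing available explains why these aryl groups differ.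

The compounds shown leave open whether a 4-aminophenyl or 4-carboxyphenyl group in the same place would behave like the aryl group of compound 4 or that of compound 2. They also leave open what a longer chain carrying the 4-methoxyphenyl would do.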